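Removing a Methyl from the Ether Oxygen of Compound 2

The source may report more compounds than this note shows. Statements on the series, on what has been measured and on what is new or still open speak of the compounds shown alone.

In a functional assay on NCI/ADR-RES cells (Homo sapiens) for cytotoxicity, read by sulforhodamine B assay, with a stated time of 48 h, tested at 100 nM (a higher number here means a weaker effect of the compound at the concentration tested, a lower number a stronger effect), compound 2 `COc1cc(C)cc(-c2nn(CC#N)cc2-c2ccnc(-c3ccc(N(C)C)cc3)c2)c1` gives -22%. Compound 1 `Cc1cc(O)cc(-c2nn(CC#N)cc2-c2ccnc(-c3ccc(Oc4ccccc4)cc3)c2)c1` gives 95% in this assay, so compound 2 stands as the lower of the two numbers, and the gap to compound 1 lies beyond the usual scatter. Going by the values given here, compound 1 and compound 2 differ in two places at once, so the two values show only that the pair differs, not which change carries the difference. Compound 3 `Cc1cc(O)cc(-c2nn(CC#N)cc2-c2ccnc(-c3ccc(N(C)C)cc3)c2)c1` is the next compound to be measured. The change from compound 2 to compound 3 is hydrogen in place of methyl on an oxygen on an aromatic ring. Among the compounds with values here, no single-change step between measured compounds is available to set its size. The step from compound 2 to compound 3 is expected to be a number 22 percentage points higher from compound 2 to compound 3 (beyond the scatter), that is, none beyond the scatter. Compound 3 is therefore expected to give 0% in this assay, within a range from -30% to 50%.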

Compound 3, a percentage reported as activity, at one concentration (the size of the read-out at that concentration, not a potency): 91%
Compound 3: the middle estimate sits 91 percentage points below what was measured, and the stated range ends below it.
By their numbers in this assay, from the lowest: compound 2; then compounds 3 and 1 (each within the scatter of the next).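

In this assay, the methoxy to hydroxy change on the 3-methoxy-5-methylphenyl group, taken alone, gives a large step, a number 113 percentage points higher from compound 2 to compound 3 (beyond the scatter), so the methyl on this oxygen goes with the stronger effect in this pair. The other place behaves differently: with hydroxy held in place, dimethylamino in place of phenoxy gives a number 4 percentage points lower from compound 1 to compound 3 (within the scatter), so of the two places in which compound 1 and compound 2 differ, only the oxygen shows a step beyond the scatter. Nothing available explains the size of this step.

The compounds shown leave open whether an ethoxy group, with its longer chain on the oxygen, or an amine in place of the oxygen would go with the effect seen for methoxy. They also leave open whether phenoxy and dimethylamino would remain alike with methoxy on the ring.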